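The source may report more compounds than this note shows. Statements on the series, on what has been measured and on what is new or still open speak of the compounds shown alone.

Measured so far:
compound 1, `COc1ccccc1/C=C/C(=O)/C=C/c1ccc(OCc2cn(CCOc3cc(=O)oc4ccccc34)nn2)c(OC)c1` — 70%
compound 2, `COc1cc(/C=C/C(=O)/C=C/c2ccco2)ccc1OCc1cn(CCCCOc2cc(=O)oc3ccccc23)nn1` — 47%

Both numbers come from a functional assay on HCT-116 cells (Homo sapiens) for inhibition, read by sulforhodamine B assay, with a stated time of 48 h, tested at 50 uM; a higher number here means more inhibition of growth at the concentration tested, a lower number less inhibition of growth. Compound 2 stands lowest of the two; compound 1 gives the higher figure, and that gap is beyond the scatter of this assay . For the measured compounds named here, no single-point step between measured compounds is available.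

Compound 3, `COc1cc(/C=C/C(=O)/C=C/c2cccs2)ccc1OCc1cn(CCCCOc2cc(=O)oc3ccccc23)nn1`, differs from compound 2 by thiophen-2-yl in place of furan-2-yl on a double-bonded chain carbon bound to a double-bonded chain carbon. Thiophen-2-yl in place of furan-2-yl is a small exchange of one ring hetero atom; nothing in the measured pair bears on it. A step of a number 3 percentage points higher from compound 2 to compound 3 (within the scatter) is expected to be small, within the scatter, with no direction favoured. Compound 3 is estimated at 50%, in the range 35% to 65%.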

Compound 3, percent growth inhibition at one concentration: 41%
For compound 3 the middle estimate is 9 percentage points above the measured one; measured number inside the range.
By their numbers in this assay, from the lowest: compounds 3 and 2 (each within the scatter of the next); then compound 1.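

In this assay, thiophen-2-yl in place of furan-2-yl on a double-bonded chain carbon bound to a double-bonded chain carbon is read as a number 6 percentage points lower from compound 2 to compound 3 (within the scatter), so the two rings are not told apart at this position. This exchange of one ring hetero atom gives the series its first single-change reading. Nothing available bears on why the result stands as it does.

Going by these compounds, whether an amine or a carboxylic acid at this position would shift the figure beyond the scatter stays open. Compound 1 differs from compound 2 and compound 3 in more than one place, so its higher figure cannot be assigned to any single part.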